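Adding one methoxy to compound 3

A few compounds are considered here, and "the series" means these few. Any claim that something is new, unique, unknown or untested is made for them only; others in the source may bear on it.

Of the compounds shown here, three sharing one core have been measured so far. In a functional assay on SW-620 cells (Homo sapiens) for cytotoxicity, read by MTT assay, with a stated time of 72 h (on this read-out lower numbers stand for stronger inhibition and higher numbers for weaker inhibition), compound 1 `COc1ccc(/C=C2\CCC/C(=C\c3cccc(OC)c3OC)C2=O)cc1OC` gives 6400 nM and compound 2 `COc1ccc(/C=C2\CCC/C(=C\c3ccccc3Cl)C2=O)cc1OC` gives 7100 nM while compound 3 `COc1cccc(/C=C2\CCC/C(=C\c3ccc(OC)c(OC)c3)C2=O)c1` gives 3700 nM on the same read-out. Compound 3 therefore stands within the scatter of both other compounds.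

Compound 4 `COc1ccc(/C=C2\CCC/C(=C\c3ccc(OC)c(OC)c3)C2=O)cc1OC` differs from compound 3 by methoxy in place of hydrogen on an aromatic carbon and the new methoxy stands ortho to a methoxy group and para to a large group.

Going by the values given here, two measured steps bear on this change. The closer one is the opposite kind of exchange, hydrogen in place of methoxy on an aromatic carbon, though at a different carbon. It amounts to a 1.7-fold lower number from compound 1 to compound 3 (0.24 log units; within the scatter) and lies within the scatter. The other, 3-methoxyphenyl in place of 2-chlorophenyl, amounts to a 1.9-fold lower number from compound 2 to compound 3 (0.28 log units; within the scatter) and also lies within the scatter. Neither step therefore supports a change beyond the scatter in this assay and neither settles a direction.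

The expected step is a 1.2-fold higher number from compound 3 to compound 4 (0.09 log units; within the scatter) and it is estimated to stay within the scatter. For compound 4 the estimated value is 4500 nM with an expected range from 2000 nM to 10000 nM on this read-out.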

Compound 4, half-maximal inhibitory concentration: 4500 nM
Compound 4: middle estimate and measured number agree at the digits printed, and the stated range covers the measured number.
By their numbers in this assay, from the lowest: compounds 3, 4, 1 and 2 (each within the scatter of the next).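

Going by these compounds alone, until now, the only exchange of hydrogen and methoxy on an aromatic carbon had been read at a different carbon, so this position had no measured step of its own. Here, on the carbon ortho to a methoxy group and para to a large group, the exchange gives in this assay a step (a 1.2-fold higher number from compound 3 to compound 4 (0.09 log units; within the scatter)) that stays within the scatter, so this assay does not tell hydrogen and methoxy apart at this carbon. Nothing available bears on what lies behind this result.

What the compounds shown leave open is whether any group at this carbon can move the number beyond the scatter, since they hold only hydrogen and methoxy there, and a hydroxyl, an amine, a carboxylic acid or a longer chain such as butoxy could each give a different answer. They also leave open whether the same exchange would stay within the scatter on a partner ring carrying 2-chlorophenyl, as in compound 2, instead of the ring found in compound 3.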